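Cytotoxicity notes on compounds 1 to 4

A few compounds are considered here, and "the series" means these few. Any claim that something is new, unique, unknown or untested is made for them only; others in the source may bear on it.

Compound 1 `CC(C)C[C@H](NC(=O)O[C@@H](C)c1ccccc1)C(=O)N[C@H](C=O)C[C@@H]1CCNC1=O`: > 200000 nM
Compound 2 `O=C[C@H](C[C@@H]1CCNC1=O)NC(=O)[C@H](CC1CC1)NC(=O)OCc1cccc(F)c1`: > 200000 nM
Compound 3 `O=C(N[C@@H](CC1CC1)C(=O)N[C@@H](C[C@@H]1CCNC1=O)C(O)S(=O)(=O)O)OCc1ccccc1`: > 200000 nM

In an ADME assay on Vero C1008 cells (Chlorocebus sabaeus) for cytotoxicity, read by luminescence and CellTiter-Glo, with a stated time of 24 h (a higher number here means that more compound is tolerated, a lower number that less compound is tolerated), compound 1 gives > 200000 nM, which is a limit of the assay and not a measured number. Compound 2 likewise reaches only a limit, > 200000 nM. For compound 3 the reading is again a limit, > 200000 nM. Going by the values given here, no two of these three compounds differ in one place, so no measured step exists among them; what can be said is that every value sits at the same place, (the limit of > 200000 nM in this assay, at which 3 of the 3 values shown sit).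

Compound 4 `COc1cccc2[nH]c(C(=O)N[C@@H](CC3CC3)C(=O)N[C@@H](C[C@@H]3CCNC3=O)C(O)S(=O)(=O)O)cc12` is not yet measured. It differs from compound 3 by 4-methoxy-1H-indol-2-yl in place of benzyloxy on a carbonyl carbon. Among the compounds with values here, because the limit of > 200000 nM in this assay, at which 3 of the 3 values shown sit, holds for all three compounds so far, no step beyond the usual scatter is expected from compound 3 to compound 4, and compound 4 is expected to be reported at a limit as well. The estimate for compound 4 is 200000 nM, with a range from 100000 nM to 400000 nM. The expected step is a number no higher from compound 3 to compound 4 (the limit leaves the size open).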

Compound 4, half-maximal cytotoxic concentration: > 200000 nM
Compound 4 was reported as a limit (the forecaster's own chance of this, stated with the estimate: 80%); the middle value lies on the limit itself.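

Compound 3 and compound 4 both stand at a limit and not at a measured number, so no step can be read between them: the limit of > 200000 nM in this assay, at which 4 of the 4 values shown sit.

The compounds shown leave open at what concentration any of them becomes cytotoxic in this assay, and whether 4-methoxy-1H-indol-2-yl in place of benzyloxy shifts that concentration.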